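This account rests on a few compounds, and the source may have more. Where it says the series, first, only, none or still open, it means among the compounds named here.

Measured in a functional assay on Shh Light II cells (Mus musculus) for inhibition, read by a luciferase reporter; on this read-out higher numbers stand for weaker inhibition and lower numbers for stronger inhibition:
- compound 1 `Cn1c(-c2noc(C3CCN(C(=O)NC4CCCCC4)CC3)n2)nc2ccccc21`: 89 nM
- compound 2 `O=C(OCc1ccccc1)N1CCC(c2nc(-c3ccc4ccccc4n3)no2)CC1`: > 2500 nM (a limit)
- compound 3 `Cc1noc(C)c1NC(=O)N1CCC(c2nc(-c3ccc4ccccc4n3)no2)CC1`: 3000 nM

Compound 3, at 3000 nM, holds the higher of the two actual numbers, and compound 1 lies lower, beyond the scatter. The reading for compound 2 is only a limit, > 2500 nM.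

Compound 4 `O=C(NC1CCCCC1)N1CCC(c2nc(-c3ccc4ccccc4n3)no2)CC1` differs from compound 3 at a single place: cyclohexyl in place of 3,5-dimethyl-1,2-oxazol-4-yl on an amide-type nitrogen. Among the compounds with values here, the only measured step at this carbonyl, a step that the limit leaves unreadable from compound 2 to compound 3, gives no size to carry over. The better guide is compound 1, which also has cyclohexyl on an amide-type nitrogen, though on a different core, and gives 89 nM. A lower number, meaning stronger inhibition, is therefore expected, though probably not all the way to that of compound 1, since the cores differ. The expected change is a 10-fold lower number from compound 3 to compound 4 (1.00 log units; beyond the scatter), which would lie beyond the scatter. For compound 4 the estimated value is 300 nM, within an expected range of 70 nM to 1300 nM.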

Compound 4, half-maximal inhibitory concentration: 57 nM
For compound 4 the middle estimate is 5.3-fold (0.72 log units) above the measured one, outside the stated range (below it).
By their numbers in this assay, from the lowest: compounds 4 and 1 (each within the scatter of the next); then compound 3.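

In this assay, the group on the amide-type nitrogen proves decisive on the shared core, with cyclohexyl in place of 3,5-dimethyl-1,2-oxazol-4-yl giving a 53-fold lower number from compound 3 to compound 4 (1.72 log units; beyond the scatter). The step from benzyloxy to cyclohexylamino, an at least 43-fold lower number from compound 2 to compound 4 (1.64 log units; beyond the scatter), is only a bound, and compound 2 stands as a limit: the limit of > 2500 nM in this assay, at which 1 of the 4 values shown sits. With cyclohexyl kept in both, quinolin-2-yl in place of 1-methyl-1H-benzimidazol-2-yl gives a 1.6-fold lower number from compound 1 to compound 4 (0.19 log units; within the scatter), so the two cores cannot be told apart in this read-out.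

What stays open is how closely the effect is tied to cyclohexyl itself, since the compounds shown do not tell how cyclopentyl, phenyl or an open hexyl chain on the same nitrogen would read. Also open, on these data alone, is whether a hydroxyl or an amine on the cyclohexyl ring would be tolerated.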